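Adding 4-methylbenzyl to compound 3: what to expect

The compounds below may be only part of what the source reports. "The series", "measured", "known", "first", "only" and "open" are said of these compounds alone.

Measured in a functional assay on NCI-H460 cells (Homo sapiens) for cytotoxicity, read by MTT assay, with a stated time of 72 h; a higher number here means a weaker inhibitor, a lower number a stronger inhibitor:
- Compound 1 `CC1CCN(Cc2ccc3nc(NC(=O)N/N=C/c4cn(Cc5ccc(Cl)cc5Cl)c5ccccc45)sc3c2)CC1`: 1660 nM
- Compound 2 `CN(C)Cc1ccc2nc(NC(=O)N/N=C/c3cn(Cc4ccc(C(C)(C)C)cc4)c4ccccc34)sc2c1`: 810 nM
- Compound 3 `CC1CCN(Cc2ccc3nc(NC(=O)N/N=C/c4c[nH]c5ccccc45)sc3c2)CC1`: 4130 nM

Compound 3 has the highest number of these three, which makes it the weakest inhibitor of the set so far. Compound 4 `Cc1ccc(Cn2cc(/C=N/NC(=O)Nc3nc4ccc(CN5CCC(C)CC5)cc4s3)c3ccccc32)cc1` comes from compound 3 through a single change, 4-methylbenzyl in place of hydrogen on an aromatic nitrogen.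

For the measured compounds named here, one measured step bears directly on this change. Hydrogen in place of 2,4-dichlorobenzyl on an aromatic nitrogen gives a 2.5-fold higher number from compound 1 to compound 3 (0.40 log units; beyond the scatter), a modest loss of potency. The new change runs the opposite way, adding a substituted benzyl group rather than removing one. Compound 2 also carries a substituted benzyl group and has a lower number than compound 3, but it differs from compound 3 in a second place as well, so it offers only loose support. Going by the values given here, no measured compound yet carries 4-methylbenzyl itself.

A modest step toward a lower number is therefore expected in this assay, similar in size to the measured one, and the expected change is a 2.4-fold lower number from compound 3 to compound 4 (0.39 log units; beyond the scatter). For compound 4 the estimated value is 1700 nM, with an expected range of 800 nM to 3500 nM.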

Compound 4, half-maximal inhibitory concentration: 410 nM
The estimate for compound 4 lay 4.1-fold (0.62 log units) above the measured number; the whole stated range lies above it.
By their numbers in this assay, from the lowest: compounds 4 and 2 (each within the scatter of the next); then compound 1; then compound 3.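

In this assay the step to 4-methylbenzyl on the aromatic nitrogen gives a 10-fold lower number from compound 3 to compound 4 (1.00 log units; beyond the scatter) and so shows a second, separate case of a substituted benzyl group at this position going with a lower number than the hydrogen of compound 3. The earlier compounds shown here could not show whether the group's substituents matter, but exchanging 2,4-dichlorophenyl for 4-methylphenyl on the same saturated chain carbon gives a 4.0-fold lower number from compound 1 to compound 4 (0.61 log units; beyond the scatter) with the rest of the molecule unchanged, so at this position the number depends on what the benzyl ring carries and not only on a benzyl group being present. Nothing available here gives a reason for either step.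

Because each benzyl group shown carries substituents, the compounds leave open how plain benzyl would compare, and whether a ring is needed at all, as a simple butyl chain on the same nitrogen would test. They also leave open whether 4-methoxybenzyl or a chain ending in an amine would keep the number as low as that of compound 4.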